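This account rests on a few compounds, and the source may have more. Where it says the series, first, only, none or still open, it means among the compounds named here.

Of the compounds shown here, three have been measured in a functional assay on MCF7 cells (Homo sapiens) for inhibition, read by MTT assay, with a stated time of 48 h; a lower number here means a stronger inhibitor, a higher number a weaker inhibitor. Compound 1, `COc1cc2c(cc1OC)C(=O)/C(=C/c1cc(-c3cc(OC)c(OC)c(OC)c3)n[nH]1)C2`, gives 2000 nM in this assay. Compound 3, `COc1ccc(-c2cc(/C=C/C(=O)c3ccc(N)cc3)[nH]n2)cc1`, gives 800 nM in this assay. Compound 2, `COc1cc(-c2cc(/C=C/C(=O)c3ccc(Cl)cc3)[nH]n2)cc(OC)c1OC`, gives 11600 nM in this assay, the highest number of the three: compound 1 stands well below it, and compound 3 stands further below still, both gaps lying beyond the usual scatter. Among the measured compounds shown here, compound 2 is therefore the weakest inhibitor of the three measured so far.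

The compound now in question is compound 4, `COc1ccc(C(=O)/C=C/c2cc(-c3cc(OC)c(OC)c(OC)c3)n[nH]2)cc1OC`. It keeps the shared core of compound 2 and differs from it in a single place: 3,4-dimethoxyphenyl in place of 4-chlorophenyl on a carbonyl carbon. For the measured compounds named here, no measured pair shows this exact exchange, so its effect can only be guessed from the spread of the three measured values.

Since every measured neighbour sits below compound 2, the step from compound 2 to compound 4 is expected to go toward stronger inhibition, by about a 3.9-fold lower number from compound 2 to compound 4 (0.59 log units; beyond the scatter), beyond the scatter. For compound 4 the expected value in this assay is 3000 nM, within a range from 800 nM to 12000 nM.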

Compound 4, half-maximal inhibitory concentration: 510 nM
The estimate for compound 4 lay 5.9-fold (0.77 log units) above the measured number, outside the stated range (below it).
By their numbers in this assay, from the lowest: compounds 4 and 3 (each within the scatter of the next); then compound 1; then compound 2.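

The group on this carbonyl carbon has a strong influence on the result in this assay: with 3,4-dimethoxyphenyl in place of 4-chlorophenyl, the pair shows a 23-fold lower number from compound 2 to compound 4 (1.36 log units; beyond the scatter). The earlier compounds shown here differed from one another in more than one place, so they could not tie a change in the number to this position alone, whereas here the rest of compound 2 stays the same in compound 4. Nothing available explains why this exchange has so large an effect.

The exchange removes the chlorine and adds two methoxy groups at once, so it remains open which of these changes accounts for the step. Compounds with a plain phenyl or a phenyl bearing a single methoxy group on the same carbonyl carbon could help separate those contributions.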